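Ether side chains on the core of compound 1

The source may hold more compounds than are shown below. What is called first, only, known or untested is meant among the compounds shown, and "the series" means these compounds.

Compound 1 `NC1C[C@@H](N)[C@@H](O)C(O)[C@H]1OCSc1ccnc2cc(C(F)(F)F)ccc12`: 35000 nM
Compound 2 `NCCCNCCO[C@H]1C(O)[C@@H](OCSc2ccnc3cc(C(F)(F)F)ccc23)C(N)C[C@H]1N`: 1500 nM
Compound 3 `CN(C)CCCNC(=O)CO[C@H]1C(O)[C@@H](OCSc2ccnc3cc(C(F)(F)F)ccc23)C(N)C[C@H]1N`: 241000 nM

In an assay on nucleic acid with ribosomal RNA A-site as the target (on this read-out higher numbers stand for weaker binding and lower numbers for tighter binding), compound 1 holds the second highest of the three numbers, at 35000 nM. Compound 4 `CN(C)CCCNC(=O)COC1[C@@H](OCSc2ccnc3cc(C(F)(F)F)ccc23)C(N)C[C@@H](N)[C@H]1O` is not yet measured. Its change from compound 1 is ((3-(dimethylamino)propyl)carbamoyl)methyl in place of hydrogen on an oxygen on a saturated carbon. The same group stands on a different oxygen in compound 3. The closest guide is therefore a 6.9-fold higher number from compound 1 to compound 3 (0.84 log units; beyond the scatter). A different chain reversed the direction: a 23-fold lower number from compound 1 to compound 2 (1.37 log units; beyond the scatter). The gap separating those two chains is large: a 160-fold higher number from compound 2 to compound 3 (2.21 log units; beyond the scatter). A modest rise in this assay is therefore expected, with its size uncertain since the oxygen differs. The expected step is a 2.3-fold higher number from compound 1 to compound 4 (0.36 log units; beyond the scatter). Compound 4 is estimated at 80000 nM, with an expected range of 15000 nM to 300000 nM.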

Compound 4, dissociation constant: 88000 nM
Compound 4: middle estimate off by 1.1-fold (0.04 log units), on the low side, and the stated range covers the measured number.
By their numbers in this assay, from the lowest: compound 2; then compound 1; then compound 4; then compound 3.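

In this assay the ((3-(dimethylamino)propyl)carbamoyl)methyl group on this oxygen gives a 2.5-fold higher number from compound 1 to compound 4 (0.40 log units; beyond the scatter) and so points the same way as a 6.9-fold higher number from compound 1 to compound 3 (0.84 log units; beyond the scatter) on the other oxygen. The rise with this chain is thus not tied to one oxygen, though only these two compounds carry it, and compound 2 goes against it with a 23-fold lower number from compound 1 to compound 2 (1.37 log units; beyond the scatter) for its different chain.

From the compounds shown here alone, whether 2-((3-aminopropyl)amino)ethyl on this oxygen would also lower the number, and what a carboxylic acid at the chain end would do, stays open. No measured evidence on hand gives a reason for the rise.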